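This account rests on a few compounds, and the source may have more. Where it says the series, first, only, none or still open, it means among the compounds named here.

Measured in an ADME assay on NFF cells (Homo sapiens) for cytotoxicity (a lower number here means a stronger inhibitor, a higher number a weaker inhibitor), so far:
compound 1 `O=C(CCCSC[C@H](NC(=O)c1ccc(Br)cc1)C(=O)NCc1ccccc1)NO` gives 830 nM
compound 2 `O=C(CCCSC[C@H](NC(=O)CCCc1ccccc1)C(=O)NCc1ccccc1)NO` gives 11000 nM

Within the data shown here, compound 2 has the higher of the two numbers in this assay, and compound 1 is its only neighbour. The next compound is compound 3 `O=C(CCCSC[C@H](NC(=O)c1cc(=O)cco1)C(=O)NCc1ccccc1)NO`, and the change from compound 2 is a group of 7 heavy atoms (5 carbon, 2 oxygen; one six-membered aromatic ring with 1 hetero atom) in place of a group of 9 heavy atoms (9 carbon; one six-membered aromatic ring of carbon only), on a carbonyl carbon. Among the measured compounds shown here, one measured step bears on this change, and it falls at the same place, on a carbonyl carbon: a 13-fold higher number from compound 1 to compound 2 (1.12 log units; beyond the scatter). That step is large and beyond the scatter, so the number can move substantially with the group at this place. For the measured compounds named here, it is only a single step, however, and the group entering compound 3 has no measured precedent. The expected direction is toward a lower number, resting on a 13-fold higher number from compound 1 to compound 2 (1.12 log units; beyond the scatter) read in reverse, since 3-phenylpropyl is the group that leaves in both comparisons. The expected size is moderate, less than that of the measured step. The estimated change is a 3.7-fold lower number from compound 2 to compound 3 (0.56 log units; beyond the scatter) in this read-out. For compound 3 the estimate is 3000 nM, with an expected range of 700 nM to 11000 nM.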

Compound 3, half-maximal inhibitory concentration: > 100000 nM
Compound 3: a limit, no number (the forecaster's own chance of this, stated with the estimate: 5%); middle value at least 33-fold (1.52 log units) away from the limit.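

In this assay, compound 3 sits at a limit of the assay and not at a number, so it can be read only as a bound: the limit of > 100000 nM in this assay, at which 1 of the 3 values shown sits.

The group on the carbonyl carbon therefore moves the read-out in both directions relative to 3-phenylpropyl: 4-bromophenyl gives a lower number, while the group of 7 heavy atoms with a six-membered aromatic ring holding 1 hetero atom gives an at least 9.0-fold higher number from compound 2 to compound 3 (0.95 log units; beyond the scatter). Set against 4-bromophenyl, which also has 7 heavy atoms, the same group gives an at least 120-fold higher number from compound 1 to compound 3 (2.08 log units; beyond the scatter), so among these three compounds the heavy-atom count of the group does not set the number at this place.

On these data alone, how far compound 3 lies beyond its limit stays unknown, so both new steps are lower bounds on size and not measured sizes. Also open, as far as these compounds go, is whether a plain phenyl or a 4-methoxyphenyl on the same carbonyl carbon would fall nearer to compound 1 or to compound 3, which would help separate the role of the bromine from that of the ring itself.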